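Removing the nitrogen allyl chain from compound 1

The source may report more compounds than this note shows. Statements on the series, on what has been measured and on what is new or still open speak of the compounds shown alone.

Measured in a functional assay on HepG2 cells (Homo sapiens) for cytotoxicity, read by sulforhodamine B assay, with a stated time of 48 h; on this read-out higher numbers stand for weaker inhibition and lower numbers for stronger inhibition:
- compound 1 `C=CCn1c(-c2ccc(Cl)cc2)cc(-c2ccc(Cl)cc2)c(C#N)c1=O` gives 20 ug/mL
- compound 2 `CCn1c(-c2ccc(Cl)cc2)cc(-c2ccc(Cl)cc2)c(C#N)c1=O` gives 22.3 ug/mL
- compound 3 `N#Cc1c(-c2ccc(Cl)cc2)cc(-c2ccc(Cl)cc2)n([C@@H]2O[C@H](COC(=O)c3ccccc3)[C@@H](OC(=O)c3ccccc3)[C@H]2OC(=O)c2ccccc2)c1=O` gives 8 ug/mL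

Compound 1 stands second highest of the three numbers; compound 2 sits within the scatter of it, and compound 3 gives a lower number beyond the scatter. Compound 4 `N#Cc1c(-c2ccc(Cl)cc2)cc(-c2ccc(Cl)cc2)[nH]c1=O` differs from compound 1 by hydrogen in place of allyl on an aromatic nitrogen. Among the measured compounds shown here, the one step that bears on this change is a 1.1-fold higher number from compound 1 to compound 2 (0.05 log units; within the scatter), a within-scatter shift when the chain on the nitrogen was shortened. For the measured compounds named here, no measured compound carries a bare hydrogen there, so the step is expected to be small, with no confident direction. The estimated step is a 1.3-fold higher number from compound 1 to compound 4 (0.10 log units; within the scatter). Compound 4 is therefore estimated at 25 ug/mL, within 12 ug/mL to 50 ug/mL.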

Compound 4, half-maximal inhibitory concentration: "not active" (no number reported)
Compound 4: no number reported; there is nothing to compare the estimate with.
By their numbers in this assay, from the lowest: compound 3; then compounds 1 and 2 (each within the scatter of the next).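

Among the compounds shown here, compound 4 is recorded as "not active" with no number, so no step from compound 1 to compound 4 can be read. The compounds shown leave open how large that change is. No supporting evidence bears on this result.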